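A few compounds are considered here, and "the series" means these few. Any claim that something is new, unique, unknown or untested is made for them only; others in the source may bear on it.

Compound 1, `C=C1CC[C@@H]2[C@](C)(CCC[C@]2(C)C(=O)OC)[C@H]1CCc1ccc2c(OC(C)=O)ccc(OC(C)=O)c2c1`, and compound 2, `C=C1[C@H](O)C[C@@H]2[C@](C)(CCC[C@]2(C)C(=O)OC)[C@H]1CCc1ccc2c(OC(C)=O)ccc(OC(C)=O)c2c1`, share one core; compound 2 carries a hydroxy where compound 1 has a hydrogen, the change being (hydroxy in place of hydrogen on a saturated ring carbon). In a functional assay on HT-29 cells (Homo sapiens) for cytotoxicity, read by sulforhodamine B assay, with a stated time of 72 h (on this read-out higher numbers stand for weaker inhibition of growth and lower numbers for stronger inhibition of growth), compound 1 gives 500 nM, and compound 2 gives 1000 nM. That step, a 2.0-fold higher number from compound 1 to compound 2 (0.30 log units; within the scatter), is within the scatter, so the hydroxy left the growth inhibition essentially unchanged.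

Compound 3, `COC(=O)[C@@]1(C)CCC[C@]2(C)C(CCc3ccc4c(OC(C)=O)ccc(OC(C)=O)c4c3)=C(C)CC[C@@H]12`, is built from the same atoms as compound 1 joined differently; how the two cores differ is not broken down here. In this assay compound 3 gives 240 nM, the lowest of the three numbers, and its step from compound 1 lies beyond the scatter.

Compound 4, `COC(=O)[C@@]1(C)CCC[C@]2(C)C(CCc3ccc4c(OC(C)=O)ccc(OC(C)=O)c4c3)=C(C)[C@@H](O)C[C@@H]12`, is not yet measured. It differs from compound 3 by hydroxy in place of hydrogen on a saturated ring carbon, the same kind of change as from compound 1 to compound 2, though here the hydroxy sits next to the ring atom that bears a methyl group. Since the earlier step was within the scatter, a similar small step a 2.0-fold higher number from compound 3 to compound 4 (0.30 log units; within the scatter) is expected from compound 3 to compound 4. Compound 4 is therefore estimated at 480 nM, expected between 200 nM and 1200 nM.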

Compound 4, concentration for 50% growth inhibition: 4800 nM
Estimate against measurement, compound 4: 10-fold (1.00 log units) below; measured number outside the range, above it.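

In this assay, hydroxy in place of hydrogen on a saturated ring carbon gives a 20-fold higher number from compound 3 to compound 4 (1.30 log units; beyond the scatter), a much larger weakening of growth inhibition than the same kind of change produced on the core of compound 1. The effect of this change therefore did not carry over unchanged from one core to the other, and the two steps truly differ: the same change on two cores in this assay, a 2.0-fold higher number (0.30 log units; within the scatter) from compound 1 to compound 2 and a 20-fold higher number (1.30 log units; beyond the scatter) from compound 3 to compound 4, 10-fold (1.00 log units) apart, beyond the scatter of two such steps. This does not show why they differ, and one pair on each core gives no rule for predicting the size of the step on any further core in this series.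

The compounds shown leave open whether the weakening on the core of compound 3 belongs to the hydroxy itself or would also follow from a methoxy, a fluorine or an amine on the same ring carbon. They also leave open whether a hydroxy elsewhere on that six-membered ring would have a similar effect.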